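The source may report more compounds than this note shows. Statements on the series, on what has been measured and on what is new or still open speak of the compounds shown alone.

Working notes on the series. In a functional assay on HEL cells (Homo sapiens) (on this read-out higher numbers stand for lower toxicity in this test and lower numbers for higher toxicity in this test), compound 1 `Cc1cn([C@@H]2O[C@@H]3COC(=O)[C@]3(OS(C)(=O)=O)[C@H]2O)c(=O)[nH]c1=O` gives only a limit, >= 36000 nM, so no number stands for it. Compound 2 `C=C(C)C(=O)NC(=O)NC1=CS(=O)(=O)O[C@@]12[C@@H](CO[Si](C)(C)C(C)(C)C)O[C@@H](n1cc(C)c(=O)n(C)c1=O)[C@@H]2O[Si](C)(C)C(C)(C)C` gives 1200 nM in this assay. Compound 3 `CCOC(=O)CNC(=O)NC1=CS(=O)(=O)O[C@@]12[C@@H](CO[Si](C)(C)C(C)(C)C)O[C@@H](n1cc(C)c(=O)n(C)c1=O)[C@@H]2O[Si](C)(C)C(C)(C)C` gives 13000 nM in this assay, the highest of the two numbers recorded; its nearest neighbour is compound 2, reached by the step of an 11-fold higher number from compound 2 to compound 3 (1.03 log units; beyond the scatter). One value in this assay sits at a limit (the limit of >= 36000 nM in this assay, at which 1 of the 3 values shown sits).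

The next compound, compound 4 `Cc1cn([C@@H]2O[C@H](CO[Si](C)(C)C(C)(C)C)[C@@]3(OS(=O)(=O)C=C3NCCC(=O)OCc3ccccc3)[C@H]2O[Si](C)(C)C(C)(C)C)c(=O)n(C)c1=O`, differs from compound 3 by 2-(benzyloxycarbonyl)ethyl in place of ((ethoxycarbonyl)methyl)carbamoyl on an amine nitrogen. This is not a single-place swap of the kind seen from compound 2 to compound 3: the whole ((ethoxycarbonyl)methyl)carbamoyl leaves and a 2-(benzyloxycarbonyl)ethyl enters on the amine nitrogen. The only step measured so far, from compound 2 to compound 3, moved the number by the amount given above when one acyl was exchanged for another on the amide-type nitrogen; no measured step covers loss of the carbamoyl. With an ester retained in the entering group and compound 3 at 13000 nM, the expectation is a step of about a 1.3-fold lower number from compound 3 to compound 4 (0.11 log units; within the scatter) in this assay, in no firm direction. Compound 4 is therefore estimated at 10000 nM in this assay, within a range from 2000 nM to 50000 nM.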

Compound 4, half-maximal cytotoxic concentration: 200000 nM
Estimate against measurement, compound 4: 20-fold (1.30 log units) below; measured number outside the range, above it.
By their numbers in this assay, from the lowest: compound 2; then compound 3; then compound 4.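

On the amine nitrogen, loss of the carbamoyl now has a measured outcome: in this assay, 2-(benzyloxycarbonyl)ethyl in place of ((ethoxycarbonyl)methyl)carbamoyl gives a 15-fold higher number from compound 3 to compound 4 (1.19 log units; beyond the scatter), and the same group in place of ((1-methylethenyl)carbonyl)carbamoyl gives a 170-fold higher number from compound 2 to compound 4 (2.22 log units; beyond the scatter). Up to now only the group on the amide-type nitrogen had been exchanged, with the urea-type link kept, and keeping an ester in the entering group did not hold the number near that of compound 3, so compound 4 has the highest of the three numbers, meaning the lowest toxicity in this test among them. The change removes the carbamoyl and brings in the benzyl ester together, and nothing measured here points to a cause for the step.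

The compounds shown leave open whether the loss of the carbamoyl or the entry of the benzyl ester carries the step. An unsubstituted amine on the amine nitrogen, or a carboxylic acid in place of the benzyl ester, would separate the two contributions.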